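From an aromatic amine to dipropylamino on a shared core

The source may report more compounds than this note shows. Statements on the series, on what has been measured and on what is new or still open speak of the compounds shown alone.

Compounds measured in a functional assay on MGC-803 cells (Homo sapiens) for inhibition, read by sulforhodamine B assay (a lower number here means a stronger inhibitor, a higher number a weaker inhibitor), are these:
- compound 1 `CCc1ccc(NC2=CC(=O)c3nc4n(c3C2=O)[C@H]2OC[C@@H](O)[C@H]2OC4)cc1` gives 1290 nM
- compound 2 `O=C1C=C(NC2CCCC2)C(=O)c2c1nc1n2[C@H]2OC[C@@H](O)[C@H]2OC1` gives > 8000 nM (a limit, not a number)
- compound 3 `COc1ccccc1NC1=CC(=O)c2nc3n(c2C1=O)[C@H]1OC[C@@H](O)[C@H]1OC3` gives 1630 nM

Within the data shown here, only two exact readings exist here, and they sit level, with a 1.3-fold higher number from compound 1 to compound 3 (0.10 log units; within the scatter) in the data. Compound 3 therefore shares the stronger end of this small series with compound 1. For compound 2 the entry > 8000 nM is a limit of the assay.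

The next change leads to compound 4 `CCCN(CCC)C1=CC(=O)c2nc3n(c2C1=O)[C@H]1OC[C@@H](O)[C@H]1OC3`, which carries dipropylamino in place of (2-methoxyphenyl)amino on a double-bonded ring carbon. The entering group has no ring and no hydrogen-bond donor. Compound 2 also lacks an aromatic ring on that amine nitrogen, so it is the closest guide. The steps of an at least 6.2-fold higher number from compound 1 to compound 2 (0.79 log units; beyond the scatter) and an at least 4.9-fold lower number from compound 2 to compound 3 (0.69 log units; beyond the scatter) both put the compound without the aromatic ring on the weaker side. Among the measured compounds shown here, no measured compound has lost the hydrogen on that nitrogen, so the size of the change remains uncertain. Going by compound 2 and its step of an at least 4.9-fold lower number from compound 2 to compound 3 (0.69 log units; beyond the scatter) a higher number is expected in this assay for the new compound, and another limit would be no surprise. The expected change is a 3.1-fold higher number from compound 3 to compound 4 (0.49 log units; beyond the scatter) in this estimate. Compound 4 is estimated at 5000 nM with an expected range from 1800 nM to 15000 nM in this read-out.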

Compound 4, half-maximal inhibitory concentration: > 16000 nM
Compound 4: only a limit was reported; the forecaster's own chance of this, stated with the estimate: 40%; middle value at least 3.2-fold (0.50 log units) away from the limit.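

In this assay, dipropylamino on this double-bonded ring carbon costs a great deal of inhibition, with an at least 9.8-fold higher number from compound 3 to compound 4 (0.99 log units; beyond the scatter) and an at least 12-fold higher number from compound 1 to compound 4 (1.09 log units; beyond the scatter), and this is the first compound shown with no hydrogen on the amine nitrogen. Across the four compounds, the two with an aromatic ring on that nitrogen, compound 1 and compound 3, give exact readings, and no compound goes against this pattern, as compound 4 is reported only as a limit, not a number: the limit of > 16000 nM in this assay, at which 1 of the 4 values shown sits. Compound 2 is also reported as a limit, so its step to compound 4 cannot be read: the limit of > 8000 nM in this assay, at which 1 of the 4 values shown sits.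

This change removes the six-membered aromatic ring and the hydrogen-bond donor together, and the compounds shown do not separate the two losses. Readings for methyl(phenyl)amino, which has the aromatic ring but no hydrogen on the amine nitrogen, and for propylamino, which has that hydrogen but no ring, would help to tell them apart.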